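The source may report more compounds than this note shows. Statements on the series, on what has been measured and on what is new or still open speak of the compounds shown alone.

Measured in a functional assay, read by Griess assay, with a stated time of 2.5 h; on this read-out higher numbers stand for weaker inhibition and lower numbers for stronger inhibition:
- compound 1 `COc1ccc(C(=O)/C=C/c2cc(OC)c(OC)cc2OC)cc1`: 2.07 ug/mL
- compound 2 `COc1cc(OC)c(OC)cc1/C=C/C(=O)c1ccc(F)cc1`: 1.96 ug/mL

Only these two compounds have been measured so far, and they cannot be told apart. Compound 2 gives 1.96 ug/mL, and the step to it is a 1.1-fold lower number from compound 1 to compound 2 (0.02 log units; within the scatter).

Compound 3 `COc1cc(OC)c(OC)cc1/C=C/C(=O)c1ccc([N+](=O)[O-])cc1` has nitro in place of fluoro on an aromatic carbon, para to a large group: nitro in place of fluoro on an aromatic carbon. Among the measured compounds shown here, one measured step bears on this change, at that same place: a 1.1-fold lower number from compound 1 to compound 2 (0.02 log units; within the scatter). For the measured compounds named here, it exchanged methoxy for fluoro, so it gives only indirect guidance, and no measured compound carries a nitro group. With so little evidence, no shift beyond the scatter is expected in this assay, and no direction can be favoured. The expected change is a 1.0-fold higher number from compound 2 to compound 3 (0.01 log units; within the scatter). For compound 3 the estimated value is 2 ug/mL, with an expected range of 0.8 ug/mL to 5 ug/mL.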

Compound 3, half-maximal inhibitory concentration: 1.98 ug/mL
Estimate against measurement, compound 3: 1.0-fold (0.00 log units) above, and the stated range covers the measured number.
By their numbers in this assay, from the lowest: compounds 2, 3 and 1 (each within the scatter of the next).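

In this assay the exchange of fluoro for nitro on an aromatic carbon, para to a large group, is a step within the scatter (a 1.0-fold higher number from compound 2 to compound 3 (0.00 log units; within the scatter)), and the exchange of methoxy for nitro at the same place is too (a 1.0-fold lower number from compound 1 to compound 3 (0.02 log units; within the scatter)). With nitro, which brings 3 heavy atoms where fluoro has 1, this position now holds three different groups whose compounds cannot be told apart on this read-out, so no exchange tried here separates them. No measured finding is at hand that would account for this result.

As far as these compounds go, whether an amine or a carboxylic acid at this place would move the number beyond the scatter remains open. So does whether any change elsewhere on the core of compound 1 would do so.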